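The compounds below may be only part of what the source reports. "The series", "measured", "known", "first", "only" and "open" are said of these compounds alone.

Among the compounds with values here, compound 1 `CC1=CC[C@@H]([C@@](C)(O)CCCC(C)(C)NC(=S)N/N=C\c2ccccc2)CC1` is one of only two compounds measured here. In a functional assay on UACC-62 cells (Homo sapiens) for cytotoxicity, read by sulforhodamine B assay (a higher number here means that more compound is tolerated, a lower number that less compound is tolerated), compound 1 gives 48400 nM. Within the data shown here, its single neighbour is compound 2 `CC1=CC[C@@H]([C@@](C)(O)CCCC(C)(C)NC(=S)N/N=C\c2ccccc2[N+](=O)[O-])CC1`, which in this assay gives 49300 nM; the two numbers lie within the scatter of each other, so neither can be called the better tolerated. Among the measured compounds shown here, the one step joining them, a 1.0-fold higher number from compound 1 to compound 2 (0.01 log units; within the scatter), puts a nitro in place of hydrogen on an aromatic carbon and leaves the read-out unchanged.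

Compound 3 `CC1=CC[C@@H]([C@@](C)(O)CCCC(C)(C)NC(=S)N/N=C\c2ccccc2Cl)CC1` is not yet measured. It differs from compound 1 by chloro in place of hydrogen on an aromatic carbon, ortho to a large group, so that phenyl becomes 2-chlorophenyl. For the measured compounds named here, the only measured step that bears on this change is the one from compound 1 to compound 2, a substitution on the same aromatic carbon, and it was within the scatter. On that basis no step beyond the scatter is expected for compound 3 in this assay, and the expected step is a 1.0-fold lower number from compound 1 to compound 3 (0.00 log units; within the scatter). The estimate for compound 3 in this assay is 48000 nM, with a range from 24000 nM to 96000 nM.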

Compound 3, concentration lethal to 50% of the cells: > 100000 nM
Compound 3: a limit, no number; the forecaster's own chance of this, stated with the estimate: 5%; at least 2.0-fold (0.31 log units) between middle value and limit.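

Compound 3 carries no number in this assay, only a limit of the assay: the limit of > 100000 nM in this assay, at which 1 of the 3 values shown sits. This shows that the aromatic carbon ortho to a large group is not indifferent to every replacement of hydrogen: phenyl to 2-chlorophenyl gives an at least 2.0-fold higher number from compound 1 to compound 3 (0.31 log units; beyond the scatter) in this read-out, so more of compound 3 is tolerated, whereas nitro on the same carbon had produced no step beyond the scatter. The direct exchange of nitro for chloro gives an at least 2.0-fold higher number from compound 2 to compound 3 (0.30 log units; that floor lies within the scatter) and, with that floor as the only figure available, the pair does not yet show a firm separation, although the step from the unsubstituted phenyl does.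

On these data alone, a limit gives no size, so how far compound 3 lies from compound 1 and compound 2 remains unknown, and a single chloro cannot show whether the effect belongs to chloro alone. Whether fluoro, bromo, methyl or methoxy in place of hydrogen on this aromatic carbon would read like chloro or like nitro stays open, as does the reason for the difference between those two groups.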